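Replacing the propargyl chain of compound 3

A few compounds are considered here, and "the series" means these few. Any claim that something is new, unique, unknown or untested is made for them only; others in the source may bear on it.

In a functional assay on the whole organism with Rattus norvegicus as the target (a higher number here means that more compound is needed for the effect, a lower number that less compound is needed), compound 1 `C[Si](C)(C)c1ccc2nc(N)sc2c1` gives 5 mg/kg, compound 2 `Nc1nc2ccc(CC(F)(F)F)cc2s1` gives 8 mg/kg and compound 3 `C#CCn1c(=N)sc2cc(OC(F)(F)F)ccc21` gives 4 mg/kg. The value of compound 3 lies within the usual scatter of the other two, so all three read alike. Compound 4 `CNS(=O)(=O)CCn1c(=N)sc2cc(OC(F)(F)F)ccc21` differs from compound 3 in one place: (methylsulfamoyl)methyl in place of ethynyl on a saturated chain carbon bound to an aromatic nitrogen. In words, (methylsulfamoyl)methyl stands in place of ethynyl on a saturated chain carbon bound to an aromatic nitrogen. The same change can be read as propargyl to 2-(methylsulfamoyl)ethyl. For the measured compounds named here, the only measured step, a 1.6-fold higher number from compound 1 to compound 2 (0.20 log units; within the scatter), exchanges a group on an aromatic carbon, not on this chain, and it stays within the scatter. It offers little guidance here, and the data show no direction for the new chain. No step beyond the scatter is therefore expected. The estimated step is a 1.5-fold higher number from compound 3 to compound 4 (0.18 log units; within the scatter). For compound 4 the expected value is 6 mg/kg, with an estimated range from 2 mg/kg to 18 mg/kg. Going by the values given here, the range is kept wide: no measured compound carries this chain.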

Compound 4, dose for half-maximal effect: 4 mg/kg
Estimate against measurement, compound 4: 1.5-fold (0.18 log units) above; measured number inside the range.
By their numbers in this assay, from the lowest: compounds 3, 4, 1 and 2 (each within the scatter of the next).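

For the compounds shown here, this is the only measured step at this place, on a saturated chain carbon bound to an aromatic nitrogen. In this assay the change from propargyl to 2-(methylsulfamoyl)ethyl gives no change at the digits printed from compound 3 to compound 4 (within the scatter) and so leaves the dose needed for the effect where it was. The entering (methylsulfamoyl)methyl, unlike ethynyl, brings a hydrogen-bond donor and hydrogen-bond acceptors, so this place accepts a much larger group, and one of a different kind, with no visible cost in this whole-animal read-out. Nothing available explains why the number holds. As far as these compounds go, whether an amine or a carboxylic acid in this chain, or a longer chain, would also leave the number in place stays open. So does whether the same exchange would read alike with a group other than the one on the aromatic carbon of compound 3.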